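This account rests on a few compounds, and the source may have more. Where it says the series, first, only, none or still open, it means among the compounds named here.

Measured so far in a functional assay on SU-DHL-6 cells (Homo sapiens) for antiproliferative activity, read by CCK-8 assay, with a stated time of 72 h; on this read-out lower numbers stand for stronger inhibition and higher numbers for weaker inhibition:
compound 1 `COc1ncc(-c2ccc3ncnc(N[C@H]4CCN(C(=O)C5CC5)C4)c3c2)cc1NS(C)(=O)=O` — 3000 nM
compound 2 `COc1ncc(-c2ccc3ncnc(NCCN4CCCCC4)c3c2)cc1NS(C)(=O)=O` — 320 nM

Compound 1 stands highest of the two numbers. Its nearest neighbour is compound 2, and the step of a 9.4-fold lower number from compound 1 to compound 2 (0.97 log units; beyond the scatter) exchanges the whole substituent on the aromatic nitrogen, so it says nothing about the acyl group on the ring nitrogen. Compound 3 `COc1ncc(-c2ccc3ncnc(N[C@H]4CCN(C(=O)C(C)(C)C)C4)c3c2)cc1NS(C)(=O)=O` differs from compound 1 only by tert-butyl in place of cyclopropyl on a carbonyl carbon. For the measured compounds named here, no measured step bears on this change, so no step beyond the scatter is expected. Compound 3 is estimated at 3000 nM in this assay, with a range from 1000 nM to 9000 nM. The expected step is no change at the digits printed from compound 1 to compound 3 (within the scatter).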

Compound 3, half-maximal inhibitory concentration: 7600 nM
Estimate against measurement, compound 3: 2.5-fold (0.40 log units) below, and the stated range covers the measured number.
By their numbers in this assay, from the lowest: compound 2; then compound 1; then compound 3.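

The group on the carbonyl carbon is not silent in this assay: tert-butyl in place of cyclopropyl gives a 2.5-fold higher number from compound 1 to compound 3 (0.40 log units; beyond the scatter), a modest step. The exchange of the whole substituent on the aromatic nitrogen remains the larger change, with a 24-fold higher number from compound 2 to compound 3 (1.38 log units; beyond the scatter) when 1-((tert-butyl)carbonyl)pyrrolidin-3-yl replaces 2-(piperidin-1-yl)ethyl. No measurement at hand gives a reason for either step.

Open, going by these compounds, is how a methyl, a longer alkyl chain or an aromatic ring on the same carbonyl carbon would read. Also open, on these data alone, is whether a pyrrolidin-3-yl with a free ring amine would approach compound 2.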